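A few compounds are considered here, and "the series" means these few. Any claim that something is new, unique, unknown or untested is made for them only; others in the source may bear on it.

Compound 1 `Nc1ncnc2c1nc(Cl)n2Cc1ccccc1`: > 10 uM in a functional assay (spleen, spleen) for activation, with Mus musculus as the target; a lower number here means that less compound is needed, a higher number that more compound is needed for the effect
Compound 2 `Nc1ncnc2c1nc(O)n2C1CCCC1`: > 10 uM in this assay

Both of these values are limits of the assay, not numbers. Compound 1 stands at the limit because of the limit of > 10 uM in this assay, at which 2 of the 2 values shown sit. Compound 2 sits at that same limit. Compound 3 `NNc1nc2c(N)ncnc2n1Cc1ccccc1` differs from compound 1 in one place: aminoamino in place of chloro on an aromatic carbon. No measured step joins two of these compounds, so no size of change has yet been seen in this assay. The expected step is a number no higher from compound 1 to compound 3 (the limit leaves the size open), which lies within the usual scatter. For compound 3 the estimate in this assay is 10 uM, with a range from 3 uM to 30 uM.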

Compound 3, minimum effective concentration: > 10 uM
Compound 3: a limit, no number (the forecaster's own chance of this, stated with the estimate: 60%); the middle value lies on the limit itself.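

No step can be read from compound 1 to compound 3, because both values are limits and not numbers: the limit of > 10 uM in this assay, at which 3 of the 3 values shown sit. The compounds shown leave open whether aminoamino in place of chloro changes the amount needed for the effect.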